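Isopropyl on the (carboxymethyl)amino chain: compound 3 to compound 4

The source may report more compounds than this note shows. Statements on the series, on what has been measured and on what is new or still open speak of the compounds shown alone.

Values measured in a functional assay on Fem-X cells (Homo sapiens) for cytotoxicity, read by MTT assay, with a stated time of 72 h (a higher number here means a weaker inhibitor, a lower number a stronger inhibitor), so far
compound 1 `CC1=CCC[C@H]2[C@](C)(CC3=CC(=O)C=CC3=O)[C@@H](C)CC[C@]12C` gives 40300 nM
compound 2 `CC1=CCC[C@H]2[C@](C)(CC3=CC(=O)C=C(NCCC(=O)O)C3=O)[C@@H](C)CC[C@]12C` gives 20200 nM
compound 3 `CC1=CCC[C@H]2[C@](C)(CC3=CC(=O)C=C(NCC(=O)O)C3=O)[C@@H](C)CC[C@]12C` gives 17800 nM

Compound 3 cannot be told apart from compound 2 on these numbers, and only compound 3 is separated from compound 1 by more than the scatter. The steps are a 2.3-fold lower number from compound 1 to compound 3 (0.35 log units; beyond the scatter), a 2.0-fold lower number from compound 1 to compound 2 (0.30 log units; within the scatter) and a 1.1-fold lower number from compound 2 to compound 3 (0.05 log units; within the scatter).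

The next structure, compound 4 `CC1=CCC[C@H]2[C@](C)(CC3=CC(=O)C=C(N[C@@H](C(=O)O)C(C)C)C3=O)[C@@H](C)CC[C@]12C`, carries isopropyl in place of hydrogen on a saturated chain carbon bound to an amine nitrogen and a carbonyl carbon.

Among the compounds with values here, no measured step places a group on this carbon. The closest evidence is a change within the same chain, a 1.1-fold lower number from compound 2 to compound 3 (0.05 log units; within the scatter), and it is small. The steps that introduce the chain are also modest or smaller, so no large move is expected in this assay, and no direction is supported.

The expected change is a 1.0-fold lower number from compound 3 to compound 4 (0.02 log units; within the scatter), which is estimated to stay within the scatter.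

For compound 4 the estimated value is 17000 nM, with an expected range of 7500 nM to 38000 nM.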

Compound 4, half-maximal inhibitory concentration: 11400 nM
Compound 4: middle estimate off by 1.5-fold (0.17 log units), on the high side, within the range that was stated.
By their numbers in this assay, from the lowest: compounds 4, 3, 2 and 1 (each within the scatter of the next, the first and the last beyond it).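

In this assay, the saturated chain carbon bound to an amine nitrogen and a carbonyl carbon now has a measured group, and isopropyl in place of hydrogen gives no shift that can be told from the scatter (a 1.6-fold lower number from compound 3 to compound 4 (0.19 log units; within the scatter)). Replacing 2-carboxyethyl with 1-carboxy-2-methylpropyl on the amine nitrogen reads the same way (a 1.8-fold lower number from compound 2 to compound 4 (0.25 log units; within the scatter)), while the full (1-carboxy-2-methylpropyl)amino group keeps the separation from compound 1 beyond the scatter, though it remains modest (a 3.5-fold lower number from compound 1 to compound 4 (0.55 log units; beyond the scatter)). No measurement at hand offers an explanation for these steps.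

The compounds shown leave open whether a benzyl group, a hydroxymethyl group or an aminobutyl chain on that same carbon would move the number beyond the scatter. Also open, from the compounds shown here alone, is what a methyl ester or a primary amide in place of the carboxylic acid would do.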